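This account rests on a few compounds, and the source may have more. Where it says the series, first, only, none or still open, it means among the compounds named here.

Compound 1 `C=CC1=C(C(=O)NCc2ccccc2)C(c2ccc(OC)c(OC)c2)OC1`: > 100000 nM
Compound 2 `C=CC1=C(C(=O)NCc2ccc(Cl)cc2)C(c2ccc(F)cc2)OC1`: > 100000 nM
Compound 3 `C=CC1=C(C(=O)Nc2ccc(OCC)cc2)C(c2ccc(OC)cc2)OC1`: 17600 nM

In a functional assay on A549 cells (Homo sapiens) for cytotoxicity, read by MTT assay, with a stated time of 24 h (on this read-out higher numbers stand for weaker inhibition and lower numbers for stronger inhibition), compound 2 gives > 100000 nM, and this is a limit of the assay rather than a measured number. Compound 1 also sits at a limit, > 100000 nM. Of the three compounds shown, only compound 3 returns a number, 17600 nM. Compound 2 therefore stands where most of the shown results stand, at the limit of > 100000 nM in this assay, at which 2 of the 3 values shown sit, and nothing more precise can be said about it.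

Compound 4 `C=CC1=C(C(=O)Nc2ccccc2)C(c2ccc(F)cc2)OC1` has not been tested. It differs from compound 2 in one place: phenyl in place of 4-chlorobenzyl on an amide-type nitrogen. Among the compounds with values here, no pair of measured compounds differs in only one place, so there is no measured step to lean on. The expectation is that the step from compound 2 to compound 4 in this assay is an at least 3.3-fold lower number from compound 2 to compound 4 (0.52 log units; beyond the scatter), toward stronger inhibition, though the size is uncertain since compound 2 is itself a limit. Compound 4 is estimated at 30000 nM, between 8000 nM and 100000 nM.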

Compound 4, half-maximal inhibitory concentration: > 100000 nM
Compound 4 was reported as a limit; the forecaster's own chance of this, stated with the estimate: 40%; at least 3.3-fold (0.52 log units) between middle value and limit.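

In this assay compound 4 gives > 100000 nM, which is a limit and not a number. Compound 2 also sits at a limit, so the step between compound 2 and compound 4 cannot be read. The compounds shown leave open whether phenyl in place of 4-chlorobenzyl on the amide-type nitrogen changes cytotoxicity at all.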